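A few compounds are considered here, and "the series" means these few. Any claim that something is new, unique, unknown or untested is made for them only; others in the source may bear on it.

Measured so far:
Compound 1, `Fc1ccc(C2(c3ccc(F)cc3)CNC(c3cccc(Br)c3)=N2)cc1`: 4.8 nM
Compound 2, `O=Cc1cccc(C2=NC(c3ccc(F)cc3)(c3ccc(F)cc3)CN2)c1`: 8.7 nM

Among the compounds with values here, in an assay on LM cells for displacement of a labelled ligand from Neuropeptide Y receptor type 5 (Homo sapiens) (on this read-out lower numbers stand for stronger inhibition and higher numbers for weaker inhibition), compound 2 gives 8.7 nM, the higher of the two numbers; the only measured step, a 1.8-fold higher number from compound 1 to compound 2 (0.26 log units; within the scatter), stays within the usual scatter, so the two compounds cannot be ranked. Compound 3, `Nc1cccc(C2=NC(c3ccc(F)cc3)(c3ccc(F)cc3)CN2)c1`, is the next variation on the same carbon: amino in place of formyl on an aromatic carbon. Within the data shown here, the one step on record swapped a substituent at this same place with no effect beyond the scatter, and nothing else bears on an amino group here, so no shift beyond the scatter is expected in this assay. Compound 3 is therefore estimated at 10 nM, with a range from 3 nM to 35 nM, which would mean an expected 1.1-fold higher number from compound 2 to compound 3 (0.06 log units; within the scatter).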

Compound 3, half-maximal inhibitory concentration: 300 nM
Beside the measured number, compound 3's estimate is 30-fold (1.48 log units) below it; the whole stated range lies below it.
By their numbers in this assay, from the lowest: compounds 1 and 2 (each within the scatter of the next); then compound 3.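

In this assay this place on the aromatic ring turns out not to accept every group: the change to amino gives a 34-fold higher number from compound 2 to compound 3 (1.54 log units; beyond the scatter) and, measured against bromo, a 63-fold higher number from compound 1 to compound 3 (1.80 log units; beyond the scatter) as well. The earlier pair, whose numbers could not be ranked, gave no sign that a single substituent here could matter this much, so the shared core alone does not secure a low number. No available evidence explains this loss.

From the compounds shown here alone, whether the loss is specific to amino remains open. A hydroxyl group or an acetylamino group on the same carbon could stay close to compound 2 or fall as far as compound 3.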